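The compounds below may be only part of what the source reports. "The series", "measured", "known", "first", "only" and "open" are said of these compounds alone.

Measured compounds:
- compound 1, `Cc1ccc(S(=O)(=O)/C=C/S(=O)(=O)CC2=NCCO2)cc1`, 74.2%
- compound 2, `O=S(=O)(/C=C/S(=O)(=O)c1ccccc1)CC1=NCCS1`, 30.4%
- compound 3, `Cc1ccc(S(=O)(=O)/C=C/S(=O)(=O)CC2=NCCS2)cc1`, 21.7%

These three compounds were tested in a functional assay for inhibition, tested at 100 uM; a higher number here means more inhibition at the concentration tested (going by the name of the read-out), a lower number less inhibition. Compound 3 gives the lowest of the three numbers; its nearest neighbour is compound 2, and the step of a number 8.7 percentage points lower from compound 2 to compound 3 (within the scatter) lies within the scatter, so the two cannot be ranked. Compound 1 stands much higher, and the step of a number 52.5 percentage points lower from compound 1 to compound 3 (beyond the scatter) is well beyond the scatter; that step exchanges one five-membered ring for another on the chain carbon bound to a sulfonyl sulfur, not a group on the aromatic ring.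

Compound 4, `O=S(=O)(/C=C/S(=O)(=O)c1ccc(Cl)cc1)CC1=NCCS1`, has not yet been measured. It differs from compound 3 in one place: chloro in place of methyl on an aromatic carbon. Within the data shown here, only one measured step bears on this: the step of a number 8.7 percentage points lower from compound 2 to compound 3 (within the scatter), which also changes a small group on the same aromatic carbon and stays within the scatter. Among the measured compounds shown here, no step with chloro at that position has been measured. On this evidence the step of a number 3.3 percentage points higher from compound 3 to compound 4 (within the scatter) is expected to stay within the scatter, in no clear direction. Compound 4 is therefore estimated at 25%, in the range 8% to 48%.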

Compound 4, a percentage reported as inhibition, at one concentration (the size of the read-out at that concentration, not a potency): 32.3%
Estimate against measurement, compound 4: 7.3 percentage points below, within the range that was stated.
By their numbers in this assay, from the lowest: compounds 3, 2 and 4 (each within the scatter of the next, the first and the last beyond it); then compound 1.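

The step of a number 10.6 percentage points higher from compound 3 to compound 4 (beyond the scatter) in this assay is the only one on this aromatic carbon that lies beyond the scatter, so 4-methylphenyl and 4-chlorophenyl can be told apart here, though the step is modest. The unsubstituted phenyl of compound 2 cannot be placed against either: the step of a number 1.9 percentage points higher from compound 2 to compound 4 (within the scatter) and the step of a number 8.7 percentage points lower from compound 2 to compound 3 (within the scatter) both stay within the scatter, so the two substituted compounds separate from each other but not from compound 2. Nothing available here explains why chloro and methyl differ at this position.

As far as these compounds go, what a methoxy group or an amine would give on this same aromatic carbon remains open. Also open, from the compounds shown here alone, is whether the chloro-for-methyl step would carry over to the oxygen-containing five-membered ring of compound 1, since the chloro group appears here only with the sulfur-containing ring.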